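A methoxy added to compound 3: what the earlier step suggests

This account rests on a few compounds, and the source may have more. Where it says the series, first, only, none or still open, it means among the compounds named here.

Compound 1, `COC(=O)CN1C(=O)c2ccccc2NC1c1ccccc1`: 720000 nM
Compound 2, `COC(=O)CN1C(=O)c2ccccc2NC1c1ccc(OC)cc1`: 560000 nM
Compound 3, `NNC(=O)CN1C(=O)c2ccccc2NC1c1ccccc1`: 310000 nM

In an assay on mitochondria for inhibition of Amine oxidase [flavin-containing] B (Bos taurus), read by fluorescence, with a stated time of 60 min (a higher number here means a weaker inhibitor, a lower number a stronger inhibitor), compound 3 gives the lowest of the three numbers. Its nearest neighbour is compound 2, and the gap between them lies within the scatter, so the two cannot be ordered. The gap to compound 1, a 2.3-fold lower number from compound 1 to compound 3 (0.37 log units; beyond the scatter), is beyond the scatter, though only modest in size.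

Compound 4, `COc1ccc(C2Nc3ccccc3C(=O)N2CC(=O)NN)cc1`, differs from compound 3 in one place: methoxy in place of hydrogen on an aromatic carbon. The group enters on an aromatic carbon of a six-membered aromatic ring of carbon only, at the place the structures describe as para to a large group; cut one bond further out, the change reads phenyl to 4-methoxyphenyl.

The same change has been measured once before, on the methyl ester rather than the hydrazide: a 1.3-fold lower number from compound 1 to compound 2 (0.11 log units; within the scatter). That step stayed within the scatter. On that basis the step in this assay from compound 3 to compound 4 is expected to be small and, if anything, in the lowering direction, an estimated 1.2-fold lower number from compound 3 to compound 4 (0.09 log units; within the scatter). For compound 4 the expected value in this assay is therefore 250000 nM, with a likely range from 120000 nM to 520000 nM.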

Compound 4, half-maximal inhibitory concentration: 890000 nM
Compound 4: middle estimate off by 3.6-fold (0.55 log units), on the low side; measured number above the stated range.
By their numbers in this assay, from the lowest: compounds 3, 2, 1 and 4 (each within the scatter of the next, the first and the last beyond it).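

On the hydrazide, the change from phenyl to 4-methoxyphenyl gives a step beyond the scatter, a 2.9-fold higher number from compound 3 to compound 4 (0.46 log units; beyond the scatter), while on the methyl ester the same change stayed within it, so in this assay what this change does at this position depends on the group on the carbonyl carbon: the same change on two cores in this assay, a 1.3-fold lower number (0.11 log units; within the scatter) from compound 1 to compound 2 and a 2.9-fold higher number (0.46 log units; beyond the scatter) from compound 3 to compound 4, 3.7-fold (0.57 log units) apart, beyond the scatter of two such steps

The exchange on the carbonyl carbon also reads differently once the 4-methoxyphenyl is present, with a 1.6-fold higher number from compound 2 to compound 4 (0.20 log units; within the scatter) leaving those two compounds unordered, whereas the same exchange on the phenyl compounds gave a step beyond the scatter: the same change on two cores in this assay, a 2.3-fold lower number (0.37 log units; beyond the scatter) from compound 1 to compound 3 and a 1.6-fold higher number (0.20 log units; within the scatter) from compound 2 to compound 4, 3.7-fold (0.57 log units) apart, beyond the scatter of two such steps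

Across these four compounds the two changes therefore do not act independently, and a step measured on one core did not carry over to the other.

The compounds shown leave open whether this dependence belongs to methoxy itself or would also appear with a hydroxyl group, a chlorine atom or an ethoxy group at the same place. They also leave open how the position behaves with a carboxylic acid or a primary amide on the carbonyl carbon, since only the methyl ester and the hydrazide can be compared here.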